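From Methoxy to Bromo on a Shared Core

This account rests on a few compounds, and the source may have more. Where it says the series, first, only, none or still open, it means among the compounds named here.

Of the compounds shown here, three with one shared core have been measured in a functional assay on NCI-H460 cells (Homo sapiens) for inhibition, read by sulforhodamine B assay, with a stated time of 48 h; on this read-out lower numbers stand for stronger inhibition of growth and higher numbers for weaker inhibition of growth. Compound 1 `S=C(N/N=C/c1cccs1)Nc1ccc(Cl)cc1` gives > 100000 nM, which is a limit of the assay and not a number. Compound 2 `Cc1ccc(NC(=S)N/N=C/c2cccs2)cc1` gives 80600 nM. Compound 3 `COc1ccc(NC(=S)N/N=C/c2cccs2)cc1` gives > 100000 nM, again only a limit. Compound 3 therefore stands at the limit of > 100000 nM in this assay, at which 2 of the 3 values shown sit.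

Compound 4 `S=C(N/N=C/c1cccs1)Nc1ccc(Br)cc1` has bromo in place of methoxy on an aromatic carbon, para to a large group: bromo in place of methoxy on an aromatic carbon. Going by the values given here, no measured step makes this exact change, but three change the group at this place. They show an at least 1.2-fold lower number from compound 1 to compound 2 (0.09 log units; that floor lies within the scatter) and an at least 1.2-fold higher number from compound 2 to compound 3 (0.09 log units; that floor lies within the scatter). The third gives a step that the two limits leave unreadable from compound 1 to compound 3, so it adds nothing about size. With no readable step beyond the scatter, none is expected here either. In this assay the expected move is a number no higher from compound 3 to compound 4 (the limit leaves the size open). Compound 4 is estimated at 100000 nM, with an expected range from 50000 nM to 200000 nM, and the assay may well report only a limit.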

Compound 4, concentration for 50% growth inhibition: 4700 nM
Compound 4: middle estimate off by 21-fold (1.33 log units), on the high side; the measured number lies below the stated range.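

In this assay, going by these compounds alone, this position proves able to carry a large change, which the earlier compounds gave no sign of: bromo in place of methoxy gives an at least 21-fold lower number from compound 3 to compound 4 (1.32 log units; beyond the scatter), and bromo in place of methyl gives a 17-fold lower number from compound 2 to compound 4 (1.23 log units; beyond the scatter). Even exchanging one halogen for another matters here, as bromo in place of chloro gives an at least 21-fold lower number from compound 1 to compound 4 (1.32 log units; beyond the scatter). So the gain belongs to bromo among the four groups shown, and not to halogens in general, while compound 1 and compound 3 remain at a limit of the assay: the limit of > 100000 nM in this assay, at which 2 of the 4 values shown sit.

On these data alone, what sets bromo apart from chloro stays open. The compounds shown also leave open whether iodo or fluoro at this position would follow bromo or chloro, and how an amine or a nitrile there would behave.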